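Phenyl for methyl on an aromatic oxygen

This account rests on a few compounds, and the source may have more. Where it says the series, first, only, none or still open, it means among the compounds named here.

In a functional assay on HT-29 cells (Homo sapiens) for inhibition, read by sulforhodamine B assay, with a stated time of 48 h (a higher number here means a weaker inhibitor of growth, a lower number a stronger inhibitor of growth), compound 1 `O=C(NNC(=O)c1ccc2[nH]c(-c3ccc([N+](=O)[O-])o3)nc2c1)c1ccccc1` gives 31.3 ug/mL and compound 2 `COc1cccc(C(=O)NNC(=O)c2ccc3[nH]c(-c4ccc([N+](=O)[O-])o4)nc3c2)c1` gives 31.3 ug/mL, so compound 2 stands level with compound 1. Compound 3 `O=CNNC(=O)c1ccc2[nH]c(-c3ccc([N+](=O)[O-])o3)nc2c1` gives 62.5 ug/mL and lies within the usual scatter of both.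

Compound 4 `O=C(NNC(=O)c1ccc2[nH]c(-c3ccc([N+](=O)[O-])o3)nc2c1)c1cccc(Oc2ccccc2)c1` differs from compound 2 in one place (phenyl in place of methyl on an oxygen on an aromatic ring), with phenyl in place of methyl on an oxygen on an aromatic ring, so methoxy becomes phenoxy.

Within the data shown here, three measured steps bear on this. Methoxy in place of hydrogen gives no change at the digits printed from compound 1 to compound 2 (within the scatter) and hydrogen in place of phenyl gives a 2.0-fold higher number from compound 1 to compound 3 (0.30 log units; within the scatter) while hydrogen in place of 3-methoxyphenyl gives a 2.0-fold higher number from compound 2 to compound 3 (0.30 log units; within the scatter) in these measurements. Each stays within the scatter, even where a whole aromatic ring goes. Among the measured compounds shown here, no measured compound carries phenoxy, so this evidence is indirect.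

The expected result is no change at the digits printed from compound 2 to compound 4 (within the scatter) in this assay and nothing beyond the scatter is expected. Compound 4 is estimated at 31.3 ug/mL with an expected range of 14 ug/mL to 70 ug/mL in this test.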

Compound 4, concentration for 50% growth inhibition: > 7.8 ug/mL
Compound 4: only a limit was reported (the forecaster's own chance of this, stated with the estimate: 10%); the middle value is on the limit's open side.
By their numbers in this assay, from the lowest: compounds 1, 2 and 3 (each within the scatter of the next).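

In this assay compound 4 gives > 7.8 ug/mL, which is a limit and not a number. Its steps from compound 1 and from compound 2 therefore cannot be read. The compounds shown leave open whether phenoxy in place of methoxy changes growth inhibition at all.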